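The source may hold more compounds than are shown below. What is called first, only, known or untested is meant among the compounds shown, and "the series" means these compounds.

Compound 2 `Cc1ccc(-c2nc3ccccc3o2)cc1NC(=O)c1cc([N+](=O)[O-])ccc1Cl` has no exact reading in an ADME assay on Raji cells (Homo sapiens) for cytotoxicity, with a stated time of 72 h; a lower number here means that less compound is needed, a higher number that more compound is needed for the effect. In this assay, compound 2 gives > 14000 nM, which is a limit of the assay and not a number. Compound 1 `COc1ccc(-c2nc3ccccc3o2)cc1NC(=O)c1cc([N+](=O)[O-])ccc1Cl` gives > 25000 nM, and this too is only a limit. Neither compound therefore offers an exact value to build on. Compound 3 `O=C(Nc1cc(-c2nc3ccccc3o2)ccc1F)c1cc([N+](=O)[O-])ccc1Cl` differs from compound 2 at a single site: fluoro in place of methyl on an aromatic carbon. One measured change, methyl in place of methoxy on an aromatic carbon, bears on this comparison: a step that the two limits leave unreadable from compound 1 to compound 2. Its size offers no guide, so no shift beyond the usual scatter is expected in this assay, and no direction can be given. The expected change is a step that the limit leaves unreadable from compound 2 to compound 3. For compound 3 the estimate is 20000 nM, with an expected range from 8000 nM to 50000 nM.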

Compound 3, half-maximal effective concentration: > 25000 nM
Compound 3 gave a limit, no number; the forecaster's own chance of this, stated with the estimate: 80%; at least 1.2-fold (0.09 log units) between middle value and limit.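

Among these compounds, compound 1, compound 2 and compound 3 each give only a limit in this assay, so no step between them can be read. Still open, going by these compounds, is the exact value of each compound, and so whether methoxy, methyl and fluoro differ at this site.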